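A few compounds are considered here, and "the series" means these few. Any claim that something is new, unique, unknown or untested is made for them only; others in the source may bear on it.

In an ADME assay on HepG2 cells (Homo sapiens) for cytotoxicity (on this read-out higher numbers stand for lower toxicity in this test and lower numbers for higher toxicity in this test), compound 1 `CSc1cccc(N2C(=O)CN(c3cccc(C(F)(F)F)c3)CC2C(=O)NC2CCCC2)c1` gives 20000 nM and compound 2 `CSc1cccc(N2C(=O)CN(c3cc(C(F)(F)F)ccc3C)CC2C(=O)NC2CCCC2)c1` gives 10000 nM. Compound 3 `CSc1cccc(N2C(=O)CN(c3cccc(C#N)c3)CC2C(=O)NC2CCCC2)c1` stands at > 50000 nM, which is a limit of the assay and not a number. Compound 4 `CSc1cccc(N2C(=O)CN(c3cncc(C(F)(F)F)c3)CC2C(=O)NC2CCCC2)c1` carries 5-(trifluoromethyl)pyridin-3-yl in place of 3-cyanophenyl on an amine nitrogen in a ring. The nearest measured change, cyano in place of trifluoromethyl, gave an at least 2.5-fold higher number from compound 1 to compound 3 (0.39 log units; beyond the scatter). Compound 4 brings trifluoromethyl back, so that change points the opposite way here. The replacement of the larger group in compound 2 gave an at least 5.0-fold higher number from compound 2 to compound 3 (0.69 log units; beyond the scatter), while methyl in place of hydrogen gave a 2.0-fold lower number from compound 1 to compound 2 (0.30 log units; within the scatter). Going by the values given here, no measured step covers the ring nitrogen. A modest move to a lower number is therefore expected, with the expected step being an at least 1.6-fold lower number from compound 3 to compound 4 (0.22 log units; that floor lies within the scatter). Compound 4 is estimated at 30000 nM, with an expected range of 12000 nM to 50000 nM.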

Compound 4, half-maximal cytotoxic concentration: > 50000 nM
Compound 4 was reported as a limit; the forecaster's own chance of this, stated with the estimate: 30%; middle value at least 1.6-fold (0.22 log units) away from the limit.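

In this assay, trifluoromethyl on this position no longer goes with a lower number when the aromatic ring holds a hetero atom: the change gives an at least 2.5-fold higher number from compound 1 to compound 4 (0.39 log units; beyond the scatter) with trifluoromethyl kept. Replacing 2-methyl-5-(trifluoromethyl)phenyl gives an at least 5.0-fold higher number from compound 2 to compound 4 (0.69 log units; beyond the scatter) in the same series. The step between compound 3 and compound 4 cannot be read, because both are limits and not numbers: the limit of > 50000 nM in this assay, at which 2 of the 4 values shown sit.

From the compounds shown here alone, how far either compound lies past that limit stays open. Also open, going by these compounds, is how an amine or a carboxylic acid on this aromatic ring would read out.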